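The source may hold more compounds than are shown below. What is called first, only, known or untested is meant among the compounds shown, and "the series" means these compounds.

For the measured compounds named here, compound 2 `CN1CCN(CCCS(=O)(=O)c2ccc3nc(NC(=O)NC(=O)c4cc(-n5cccc5)ccc4Cl)sc3c2)CC1` gives 0.15 nM in an assay on HEK293 cells for displacement of a labelled ligand from growth hormone secretagogue receptor type 1 (Homo sapiens), with a stated time of 60 min (a lower number here means a stronger inhibitor, a higher number a weaker inhibitor), the lowest of the two numbers so far; compound 1 `CN1CCN(CCCS(=O)(=O)c2ccc3nc(NC(=O)NC(=O)c4cccc(-n5cccn5)c4Cl)sc3c2)CC1` gives 8.8 nM in this assay. Compound 3 `CN1CCN(CCCS(=O)(=O)c2ccc3nc(NC(=O)NC(=O)c4cc(C5CC5)ccc4Cl)sc3c2)CC1` differs from compound 2 by cyclopropyl in place of 1H-pyrrol-1-yl on an aromatic carbon. Going by the values given here, no measured step swaps these two groups directly; the only step in hand, a 59-fold lower number from compound 1 to compound 2 (1.77 log units; beyond the scatter), changed both the ring and its place at once, so it bears on this change only loosely. A modest step toward a higher number is expected, a 3.3-fold higher number from compound 2 to compound 3 (0.52 log units; beyond the scatter). Compound 3 is therefore estimated at 0.5 nM, within 0.12 nM to 2 nM.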

Compound 3, half-maximal inhibitory concentration in the growth hormone secretagogue receptor type 1 assay: 0.33 nM
Beside the measured number, compound 3's estimate is 1.5-fold (0.18 log units) above it; low and high end bracket the measured number.
By their numbers in the growth hormone secretagogue receptor type 1 assay, from the lowest: compound 2; then compound 3; then compound 1.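

In the growth hormone secretagogue receptor type 1 assay, cyclopropyl para to the chloro group costs only a modest step against 1H-pyrrol-1-yl (a 2.2-fold higher number from compound 2 to compound 3 (0.34 log units; beyond the scatter)), and compound 3 still gives 0.33 nM, so a low number at this place does not depend on a five-membered aromatic ring. The large gain over compound 1 also holds with this three-membered non-aromatic ring (a 27-fold lower number from compound 1 to compound 3 (1.43 log units; beyond the scatter)). In a physicochemical assay for lipophilicity (a higher number here means a more lipophilic compound, a lower number a more polar compound), compound 2 gives 2.6 and compound 3 gives 2.9; the same pair stays within the scatter (a number 0.30 log units higher from compound 2 to compound 3 (within the scatter)), and no evidence in hand explains the step in binding.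

From the compounds shown here alone, whether an amine, a carboxylic acid or a longer alkyl chain at this place keeps the number low remains open. Going by these compounds, how much of the step from compound 1 belongs to the ring and how much to its place also remains open.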